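Thiophen-3-yl for Thiophen-2-yl on a Chlorinated Core

A few compounds are considered here, and "the series" means these few. Any claim that something is new, unique, unknown or untested is made for them only; others in the source may bear on it.

Measured compounds:
Compound 1, `OC[C@H]1O[C@@H](n2cc(F)c3c(-c4cccs4)ncnc32)[C@H](O)[C@@H]1O`: 47200 nM
Compound 2, `OC[C@H]1O[C@@H](n2cc(F)c3c(-c4ccsc4)ncnc32)[C@H](O)[C@@H]1O`: 50000 nM
Compound 3, `OC[C@H]1O[C@@H](n2cc(Cl)c3c(-c4cccs4)ncnc32)[C@H](O)[C@@H]1O`: > 50000 nM, which is a limit of the assay

All three were tested in an ADME assay on MRC5 cells (Homo sapiens) for cytotoxicity, read by MTT assay, with a stated time of 72 h; on this read-out lower numbers stand for higher toxicity in this test and higher numbers for lower toxicity in this test. Compound 2 differs from compound 1 by thiophen-3-yl in place of thiophen-2-yl on an aromatic carbon, and that step was a 1.1-fold higher number from compound 1 to compound 2 (0.03 log units; within the scatter). Compound 3 differs from compound 1 by chloro in place of fluoro on an aromatic carbon. The value of compound 3 is only a limit, (the limit of > 50000 nM in this assay, at which 1 of the 3 values shown sits). The step was an at least 1.0-fold higher number from compound 1 to compound 3 (0.02 log units; that floor lies within the scatter).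

Compound 4, `OC[C@H]1O[C@@H](n2cc(Cl)c3c(-c4ccsc4)ncnc32)[C@H](O)[C@@H]1O`, has not yet been measured. It differs from compound 3 by thiophen-3-yl in place of thiophen-2-yl on an aromatic carbon, the same change as from compound 1 to compound 2. Because that earlier step was a 1.1-fold higher number from compound 1 to compound 2 (0.03 log units; within the scatter), the step from compound 3 to compound 4 is expected to be small, a number no higher from compound 3 to compound 4 (the limit leaves the size open), in this assay. Compound 4 is therefore estimated at 50000 nM, likely between 30000 nM and 100000 nM, in this assay, and may again be reported only as a limit.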

Compound 4, half-maximal cytotoxic concentration: > 50000 nM
Compound 4 was reported as a limit; the forecaster's own chance of this, stated with the estimate: 65%; the middle value lies on the limit itself.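

Compound 4 was reported only as a limit, as compound 3 was, and this is all the result shows. In this assay chloro in place of fluoro gives a number no lower from compound 2 to compound 4 (the limit leaves the size open) and no size can be read from it. The step between compound 3 and compound 4 cannot be read, so it remains unknown whether thiophen-3-yl in place of thiophen-2-yl behaves on the core of compound 3 as it does on the core of compound 1 in this assay: the limit of > 50000 nM in this assay, at which 2 of the 4 values shown sit. Nor can chloro in place of fluoro be said to act alike on both cores: the same change on two cores in this assay, an at least 1.0-fold higher number (0.02 log units; that floor lies within the scatter) from compound 1 to compound 3 and a number no lower (the limit leaves the size open) from compound 2 to compound 4; the limit leaves it open whether they differ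

The compounds shown leave open how far the true values of compound 3 and compound 4 lie past the limit. They also leave open what an amine or a longer chain in place of the thiophene ring would give in this assay.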